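Series notes: from compound 3 to compound 4

This account rests on a few compounds, and the source may have more. Where it says the series, first, only, none or still open, it means among the compounds named here.

Compound 3 `CN(C)CCn1cnnc1-c1cc(Oc2ccc(NC(=O)N/N=C/c3c(O)ccc4ccccc34)cc2F)ccn1` gives 890 nM in a functional assay on NCI-H460 cells (Homo sapiens) for cytotoxicity, read by MTT assay, with a stated time of 72 h (on this read-out higher numbers stand for weaker inhibition and lower numbers for stronger inhibition), the second highest of the three numbers. Compound 2 `CN(C)CCn1cnnc1-c1cc(Oc2ccc(NC(=O)N/N=C/c3cccc(O)c3)cc2F)ccn1` gives 780 nM, and the two sit within the scatter: a 1.1-fold higher number from compound 2 to compound 3 (0.06 log units; within the scatter). Compound 1 `COc1ccc(OC)c(/C=N/NC(=O)Nc2ccc(Oc3ccnc(-c4nncn4CCN(C)C)c3)c(F)c2)c1` gives 2930 nM; the step of a 3.3-fold lower number from compound 1 to compound 3 (0.52 log units; beyond the scatter) lies beyond the scatter, as does a 3.8-fold lower number from compound 1 to compound 2 (0.57 log units; beyond the scatter).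

Compound 4 `COc1ccc(/C=N/NC(=O)Nc2ccc(Oc3ccnc(-c4nncn4CCN(C)C)c3)c(F)c2)cc1O` is unmeasured. The change: 3-hydroxy-4-methoxyphenyl in place of 2-hydroxynaphthalen-1-yl on a carbon with a double bond to nitrogen. The entering group carries a hydroxy as in compound 2 and a methoxy as in compound 1, so it falls between those two cases. Since a 1.1-fold higher number from compound 2 to compound 3 (0.06 log units; within the scatter) stayed within the scatter while a 3.3-fold lower number from compound 1 to compound 3 (0.52 log units; beyond the scatter) was only modest, compound 4 is expected to stay close, with a 1.2-fold higher number from compound 3 to compound 4 (0.09 log units; within the scatter). The estimate for compound 4 is 1100 nM, range 450 nM to 2700 nM.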

Compound 4, half-maximal inhibitory concentration: 620 nM
The estimate for compound 4 lay 1.8-fold (0.25 log units) above the measured number; measured number inside the range.
By their numbers in this assay, from the lowest: compounds 4, 2 and 3 (each within the scatter of the next); then compound 1.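

In this assay, methoxy in place of hydrogen on an aromatic carbon is tolerated when the hydroxy stays, with a 1.3-fold lower number from compound 2 to compound 4 (0.10 log units; within the scatter). The one-ring 3-hydroxy-4-methoxyphenyl also matches the two-ring 2-hydroxynaphthalen-1-yl within the scatter, with a 1.4-fold lower number from compound 3 to compound 4 (0.16 log units; within the scatter), while replacing 2,5-dimethoxyphenyl gives a 4.7-fold lower number from compound 1 to compound 4 (0.67 log units; beyond the scatter), so a methoxy alone does not mark the weaker compound. No measurement shown here accounts for these steps. The step from compound 1 replaces the whole group, so the share of the hydroxy remains unresolved. As far as these compounds go, how an amine or a carboxylic acid would read in place of that hydroxy remains open.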